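The source may report more compounds than this note shows. Statements on the series, on what has been measured and on what is new or still open speak of the compounds shown alone.

Working notes on the arylsulfonate series.

Three members of the series share one core. Compound 1 `CCCCCC(=O)Nc1ccc(S(=O)(=O)Oc2ccccc2C(C)C)cc1` carries a pentyl group on the carbonyl carbon, compound 2 `CC(C)C(=O)Nc1ccc(S(=O)(=O)Oc2ccccc2C(C)C)cc1` an isopropyl group there, and compound 3 `CCNC(=O)Nc1ccc(S(=O)(=O)Oc2ccccc2C(C)C)cc1` an ethylamino group in that position. In a functional assay on M21 cells (Homo sapiens) for antiproliferative activity, read by sulforhodamine B assay, with a stated time of 48 h (on this read-out lower numbers stand for stronger inhibition and higher numbers for weaker inhibition), compound 1 gives 6700 nM, compound 2 gives 11000 nM, and compound 3 gives 4700 nM. Among the compounds with values here, compound 3 thus holds the lowest of the three numbers, yet the step of a 1.4-fold lower number from compound 1 to compound 3 (0.15 log units; within the scatter) is within the scatter, and only the step of a 2.3-fold lower number from compound 2 to compound 3 (0.37 log units; beyond the scatter) lies beyond it. The step of a 1.6-fold higher number from compound 1 to compound 2 (0.22 log units; within the scatter) between the two carbonyl substituents is also within the scatter.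

Compound 4 `CCCNC(=O)Nc1ccc(S(=O)(=O)Oc2ccccc2C(C)C)cc1` differs from compound 3 by methyl in place of hydrogen on a saturated chain carbon, two bonds along the chain from an amide-type nitrogen, so the same difference read one bond further out is ethylamino to propylamino. Within the data shown here, no measured pair tests this exact change; the nearest comparison, the step from compound 1 to compound 2, swaps one alkyl chain for another and stays within the scatter. In this assay compound 4 is therefore expected to give a number close to that of compound 3, with the expected step of a 1.0-fold lower number from compound 3 to compound 4 (0.02 log units; within the scatter) falling within the scatter. The estimate for compound 4 in this assay is 4500 nM, with a range from 2300 nM to 9000 nM.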

Compound 4, half-maximal inhibitory concentration: 5100 nM
For compound 4 the middle estimate is 1.1-fold (0.05 log units) below the measured one; low and high end bracket the measured number.
By their numbers in this assay, from the lowest: compounds 3, 4, 1 and 2 (each within the scatter of the next, the first and the last beyond it).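

Lengthening ethylamino to propylamino places methyl in place of hydrogen on a saturated chain carbon, two bonds along the chain from an amide-type nitrogen, and in this assay this gives no readable change (a 1.1-fold higher number from compound 3 to compound 4 (0.04 log units; within the scatter)). Within the data shown here, this is the first pair in which only the alkyl chain on that nitrogen differs, so the position tolerates this one added methyl, although a single step cannot define a trend along the chain. Compound 4 also stands against the carbonyl substituents much as compound 3 does: the comparison with isopropyl lies beyond the scatter (a 2.2-fold lower number from compound 2 to compound 4 (0.33 log units; beyond the scatter)), while the comparison with pentyl does not (a 1.3-fold lower number from compound 1 to compound 4 (0.12 log units; within the scatter)).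

Still open, going by these compounds, is whether a longer chain such as butylamino or hexylamino, or a branched isopropylamino group, would stay within the scatter of compound 3. Equally open, on these data alone, is how a terminal amine or carboxylic acid on this chain would read in this assay. Nothing at hand offers an explanation for any of these steps.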